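A few compounds are considered here, and "the series" means these few. Any claim that something is new, unique, unknown or untested is made for them only; others in the source may bear on it.

Compound 1 `C[C@H](NC(=O)c1ncccn1)c1ccc(NC(=O)N2CC(c3cccnc3)C2)cc1` is the reference point of this small set. In a functional assay on COR-L23 cells (Homo sapiens) for antiproliferative activity, read by CellTiter-Glo, with a stated time of 72 h (a higher number here means a weaker inhibitor, a lower number a stronger inhibitor), compound 1 gives 130 nM. Compound 2 `C[C@H](NC(=O)C1CCOCC1)c1ccc(NC(=O)N2CC(c3cccnc3)C2)cc1` shares its core and differs from it in one place: oxan-4-yl in place of pyrimidin-2-yl on a carbonyl carbon. In this assay compound 2 gives 58 nM, and the step of a 2.2-fold lower number from compound 1 to compound 2 (0.35 log units; beyond the scatter) runs toward a stronger inhibitor. Compound 3 `C[C@H](NC(=O)c1ncccn1)c1ccc(NC(=O)N2CC(c3cncc(N)c3)C2)cc1` keeps the (pyrimidin-2-yl)carbonyl of compound 1 but differs at the other end; the difference between the two cores is amino in place of hydrogen on an aromatic carbon. In this assay compound 3 gives 1380 nM, the highest of the three numbers, and the step of an 11-fold higher number from compound 1 to compound 3 (1.03 log units; beyond the scatter) is a large loss.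

Compound 4 `C[C@H](NC(=O)C1CCOCC1)c1ccc(NC(=O)N2CC(c3cncc(N)c3)C2)cc1` has not yet been measured. It stands to compound 3 as compound 2 stands to compound 1: the change is oxan-4-yl in place of pyrimidin-2-yl on a carbonyl carbon, the same change that was made from compound 1 to compound 2, so that it occurs twice among these compounds. The place of the change is described in identical words for both pairs. In this assay the measured step of a 2.2-fold lower number from compound 1 to compound 2 (0.35 log units; beyond the scatter) is expected to be repeated, which as an estimate reads a 2.1-fold lower number from compound 3 to compound 4 (0.33 log units; beyond the scatter). This expectation rests on a single measured pair, so the range around it is kept wide. On that basis compound 4 is expected to give 650 nM in this assay, with the estimate running from 250 nM to 1600 nM.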

Compound 4, half-maximal inhibitory concentration: 970 nM
For compound 4 the middle estimate is 1.5-fold (0.17 log units) below the measured one, within the range that was stated.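

In this assay, among these compounds, the change from pyrimidin-2-yl to oxan-4-yl on the carbonyl carbon, carried onto the amino-bearing core, gives a 1.4-fold lower number from compound 3 to compound 4 (0.15 log units; within the scatter), and this step cannot be told apart from the one measured on the core of compound 1: the same change on two cores in this assay, a 2.2-fold lower number (0.35 log units; beyond the scatter) from compound 1 to compound 2 and a 1.4-fold lower number (0.15 log units; within the scatter) from compound 3 to compound 4, 1.6-fold (0.20 log units) apart, within the scatter of two such steps The amino in place of hydrogen on an aromatic carbon likewise carries over, remaining a large step with oxan-4-yl on the carbonyl carbon, a 17-fold higher number from compound 2 to compound 4 (1.22 log units; beyond the scatter), and agreeing with the step seen with pyrimidin-2-yl: the same change on two cores in this assay, an 11-fold higher number (1.03 log units; beyond the scatter) from compound 1 to compound 3 and a 17-fold higher number (1.22 log units; beyond the scatter) from compound 2 to compound 4, 1.6-fold (0.20 log units) apart, within the scatter of two such steps Within these four compounds, each change therefore has a similar size on both cores, but this rests on only two pairs per change in a single assay, the step on the amino-bearing core does not itself lie beyond the scatter, and nothing here shows that the agreement would hold on any other core or explains why either step has the size it has.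

The compounds shown leave open whether a cyclohexyl or a piperidin-4-yl on the carbonyl carbon would follow the same course as oxan-4-yl. They also leave open whether a methyl or a methoxy on the aromatic carbon that carries the amino group would bring a step of similar size.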